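Swapping a Sulfonamide for an Amide: Expected Solubility

The source may report more compounds than this note shows. Statements on the series, on what has been measured and on what is new or still open speak of the compounds shown alone.

Compound 1 `COc1ccc(-c2cc(-c3ccc(S(=O)(=O)NC4CC4)cc3)cnc2N)cn1`: > 100 ug/mL
Compound 2 `COc1ccc(-c2cnc(N)c(-c3ccc(OC)nc3)c2)cn1`: > 100 ug/mL

Both measurements come from a physicochemical assay for solubility, read by nephelometry, measured as kinetic solubility, at pH 2; a higher number here means a more soluble compound, a lower number a less soluble compound. In this assay compound 1 gives > 100 ug/mL, which is a limit of the assay and not a number. Compound 2 likewise gives > 100 ug/mL, again a limit. Both values sit at the limit of > 100 ug/mL in this assay, at which 2 of the 2 values shown sit, so compound 1 stands at the top of what this assay can report, and nothing separates it from compound 2.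

Compound 3 `CNC(=O)c1ccc(-c2cnc(N)c(-c3ccc(OC)nc3)c2)cc1` has not yet been measured. It differs from compound 1 in one place: methylcarbamoyl in place of cyclopropylsulfamoyl on an aromatic carbon. For the measured compounds named here, no step between two measured compounds is available to size this change, so the expectation rests on the limit already reached by compound 1. The step from compound 1 to compound 3 is expected to be a number no higher from compound 1 to compound 3 (the limit leaves the size open), which means no change beyond the usual scatter. Compound 3 is therefore expected to give about 100 ug/mL in this assay, within a range from 40 ug/mL to 200 ug/mL, most likely again reported as a limit.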

Compound 3, solubility: 50 ug/mL
Beside the measured number, compound 3's estimate is 2.0-fold (0.30 log units) above it; the measured number falls inside the stated range.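

In this assay compound 3 is the first of the compounds shown to give a measured number and not a limit, so a group on this aromatic carbon, para to a large group, does not always leave the reading at the top of the scale. Putting methylcarbamoyl in place of cyclopropylsulfamoyl gives an at least 2.0-fold lower number from compound 1 to compound 3 (0.30 log units; that floor lies within the scatter), so the change cannot yet be told apart from ordinary variation between repeated measurements, though a larger step is not ruled out. From the compounds shown here alone, the true size of the step stays unknown because compound 1 sits at a limit of the assay: the limit of > 100 ug/mL in this assay, at which 2 of the 3 values shown sit.

This single change also swaps the sulfonamide link for an amide and removes the three-membered ring, so the compounds shown cannot say which of these differences matters, or whether either does. A cyclopropylcarbamoyl group at the same place, keeping the ring with the amide, would begin to separate the two, and a carboxylic acid there would show how a quite different group reads in this assay.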